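The source may hold more compounds than are shown below. What is called first, only, known or untested is meant among the compounds shown, and "the series" means these compounds.

Compound 1, `Cc1c(NC(=O)c2ccc(C(C)(C)C)cc2)cccc1-c1ccnc2[nH]c(-c3cnn(C)c3)nc12`: 0.6 10^-6 cm/s
Compound 2, `Cc1cc(-c2ccnc3[nH]c(-c4cnn(C)c4)nc23)ccc1CNC(=O)c1ccc(C(C)(C)C)cc1`: 0.2 10^-6 cm/s
Compound 3, `Cn1cc(-c2nc3c(-c4ccc(CNC(=O)c5nc(C6(C)CC6)no5)c(F)c4)ccnc3[nH]2)cn1`: 2.8 10^-6 cm/s

All three were tested in an ADME assay on Caco-2 cells (Homo sapiens) for permeability, in the apical to basolateral direction; on this read-out lower numbers stand for lower permeability and higher numbers for higher permeability. Compound 1 gives 0.6 10^-6 cm/s and compound 2 gives 0.2 10^-6 cm/s, while compound 3 gives 2.8 10^-6 cm/s, the highest number of the three. Its distance to compound 1 and to compound 2 lies beyond the usual scatter of repeated measurements, so compound 3 can fairly be called the most permeable of the three in this assay.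

Compound 4, `Cn1cc(-c2nc3c(-c4ccc(CNC(=O)c5cc(C(C)(C)C)no5)c(F)c4)ccnc3[nH]2)cn1`, has not been measured yet. It differs from compound 3 in a single place: a group of 9 heavy atoms (7 carbon, 1 nitrogen, 1 oxygen; one five-membered aromatic ring with 2 hetero atoms) in place of a group of 9 heavy atoms (6 carbon, 2 nitrogen, 1 oxygen; one three-membered non-aromatic ring of carbon only, one five-membered aromatic ring with 3 hetero atoms), on a carbonyl carbon. Among the compounds with values here, no measured pair shows this particular change, so nothing in the data fixes its size. Starting from compound 3 with its 2.8 10^-6 cm/s, the step from compound 3 to compound 4 in this assay is expected to be modest and upward, a 1.6-fold higher number from compound 3 to compound 4 (0.21 log units; within the scatter), although a result within the scatter would not surprise. Compound 4 is therefore estimated at 4.5 10^-6 cm/s, with a likely range from 1.8 10^-6 cm/s to 11 10^-6 cm/s.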

Compound 4, apparent permeability: 3 10^-6 cm/s
The estimate for compound 4 lay 1.5-fold (0.18 log units) above the measured number; low and high end bracket the measured number.
By their numbers in this assay, from the lowest: compound 2; then compound 1; then compounds 3 and 4 (each within the scatter of the next).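

On the carbonyl carbon, putting 3-(tert-butyl)-1,2-oxazol-5-yl in place of the group with the five-membered ring of 3 hetero atoms and the three-membered carbon ring gives a 1.1-fold higher number from compound 3 to compound 4 (0.03 log units; within the scatter) in this assay. Within the data shown here, this is the first pair that differs in one place only, and it shows that these two groups of 9 heavy atoms cannot be told apart on this read-out, even though the count of hydrogen-bond acceptors in the group goes from 3 to 2. No measured property of either group is at hand that bears on this result.

Both groups carry a five-membered aromatic ring, so this single pair says little about a group of another kind on this carbonyl carbon, such as a carboxylic acid or an amine. On these data alone, whether such a group would also leave the two numbers within the scatter remains open.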